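The source may report more compounds than this note shows. Statements on the series, on what has been measured and on what is new or still open speak of the compounds shown alone.

Compounds measured so far:
compound 1 `COc1cc(NC(C)CCCNC(=O)Nc2cccc(Cl)c2)c2ncccc2c1`: 21000 nM
compound 2 `COc1cc(NC(C)CCCNC(=O)NNC(=O)Nc2ccc(Br)cc2)c2ncccc2c1`: 209000 nM
compound 3 `COc1cc(NC(C)CCCNC(=O)Nc2cccc(C(F)(F)F)c2)c2ncccc2c1`: 20000 nM

All three were tested in a functional assay on MOLT-4 cells (Homo sapiens) for inhibition, read by MTT assay, with a stated time of 72 h; a lower number here means a stronger inhibitor, a higher number a weaker inhibitor. Compound 3 stands level with compound 1 at the low end of the numbers, with a 1.1-fold lower number from compound 1 to compound 3 (0.02 log units; within the scatter). Compound 2 lies well apart from it, with a 10-fold lower number from compound 2 to compound 3 (1.02 log units; beyond the scatter).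

The next compound is compound 4 `COc1cc(NC(C)CCCNC(=O)Nc2ccc(O)cc2)c2ncccc2c1`, which has not yet been measured in this assay. It carries 4-hydroxyphenyl in place of 3-(trifluoromethyl)phenyl on an amide-type nitrogen.

Among the compounds with values here, two measured steps bear on this change. Exchanging chloro for trifluoromethyl on an aromatic carbon gave a 1.1-fold lower number from compound 1 to compound 3 (0.02 log units; within the scatter), so that exchange left the number unmoved. The much larger exchange at the same amide-type nitrogen, where ((4-bromophenyl)carbamoyl)amino replaced 3-chlorophenyl, gave a 10-fold higher number from compound 1 to compound 2 (1.00 log units; beyond the scatter). Compound 4 keeps a single phenyl ring at that nitrogen, as compound 1 and compound 3 do, so a shift of that size seems unlikely. However, no measured compound carries a 4-hydroxyphenyl group, which leaves the direction uncertain. A small move towards a higher number is expected, possibly no move beyond the scatter.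

The estimate for compound 4 is 30000 nM, with an expected range from 10000 nM to 90000 nM. This estimate means a 1.5-fold higher number from compound 3 to compound 4 (0.18 log units; within the scatter).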

Compound 4, half-maximal inhibitory concentration: 21000 nM
For compound 4 the middle estimate is 1.4-fold (0.15 log units) above the measured one, within the range that was stated.
By their numbers in this assay, from the lowest: compounds 3, 1 and 4 (each within the scatter of the next); then compound 2.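

In this assay the exchange of 3-(trifluoromethyl)phenyl for 4-hydroxyphenyl on the amide-type nitrogen gives a 1.1-fold higher number from compound 3 to compound 4 (0.02 log units; within the scatter) and the exchange of 3-chlorophenyl for the same group gives no change at the digits printed from compound 1 to compound 4 (within the scatter) so these three single-ring compounds cannot be told apart. Within the data shown here, until now the only comparison among single rings was chloro against trifluoromethyl at the same ring place, whereas the entering group here has a hydroxy group at a different ring place and brings a hydrogen-bond donor and acceptor where the leaving group has none, and still the read-out does not separate them. The one gap beyond the scatter remains the one set by the ((4-bromophenyl)carbamoyl)amino group, seen here as a 10-fold lower number from compound 2 to compound 4 (1.00 log units; beyond the scatter) and so it now sets compound 2 apart from all three single-ring compounds.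

No evidence is available that explains why these rings read alike. From the compounds shown here alone, it remains open whether 3-hydroxyphenyl would match 4-hydroxyphenyl, and whether an amine or a carboxylic acid on the phenyl ring, or a longer chain in its place on the amide-type nitrogen, would stay level with compound 1, compound 3 and compound 4.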